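The source may report more compounds than this note shows. Statements on the series, on what has been measured and on what is new or still open speak of the compounds shown alone.

Measured compounds in the series:

Compound 1 `CCSCCC12CCC(c3nnc(-c4ccccc4C(F)(F)F)n3C)(CC1)CC2`; in an assay on CHO-K1 cells for inhibition of 11-beta-hydroxysteroid dehydrogenase type 2 (Homo sapiens), read by scintillation proximity assay (a higher number here means a weaker inhibitor, a lower number a stronger inhibitor), compound 1 gives > 4000 nM, a limit.
Compound 2 `Cn1c(-c2ccccc2C(F)(F)F)nnc1C12CCC(CCS(=O)(=O)C(C)(C)C)(CC1)CC2`; compound 2 gives > 4000 nM, a limit.
Compound 3 `Cn1c(-c2ccccc2C(F)(F)F)nnc1C12CCC(CNS(C)(=O)=O)(CC1)CC2`; compound 3 gives > 4000 nM, a limit.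

Compound 3 therefore stands at the limit of this assay, not at a number, and every value shown sits at that same limit (the limit of > 4000 nM in this assay, at which 3 of the 3 values shown sit). The next compound is compound 4 `CC(C)S(=O)(=O)CCC12CCC(c3nnc(-c4ccccc4C(F)(F)F)n3C)(CC1)CC2`. The change from compound 3 to compound 4 is (isopropylsulfonyl)methyl in place of methanesulfonamido on a saturated chain carbon bound to a saturated ring carbon, on a saturated chain carbon bound to a saturated ring carbon.

Of the measured steps, the two that end at compound 3 bear most directly: a step that the two limits leave unreadable from compound 1 to compound 3 and a step that the two limits leave unreadable from compound 2 to compound 3. Both are unreadable, as is a step that the two limits leave unreadable from compound 1 to compound 2. For the measured compounds named here, no step has a readable size, so no direction or size beyond the scatter can be drawn for this assay from the data.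

Compound 4 is therefore expected to sit at or beyond the same limit, with a step that the limit leaves unreadable from compound 3 to compound 4 as the estimated step. The estimate for compound 4 is 7000 nM, with an expected range from 2500 nM to 25000 nM.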

Compound 4, half-maximal inhibitory concentration: > 4000 nM
Compound 4 was reported as a limit; the forecaster's own chance of this, stated with the estimate: 80%; the middle value is on the limit's open side.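

In this assay compound 4 gives > 4000 nM, a limit. No step from compound 1, compound 2 or compound 3 to compound 4 can be read: the limit of > 4000 nM in this assay, at which 4 of the 4 values shown sit.

The compounds shown leave open how far each lies beyond this limit, and whether any change on this chain gives a measurable value.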